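The compounds below may be only part of what the source reports. "The series", "measured", "known", "first", "only" and "open" are said of these compounds alone.

Compound 3 `COc1c(N2CCN(C/C(C)=N/NC(N)=O)C(C)C2)c(F)cc2c(=O)c(C(=O)O)cn(C3CC3)c12` was tested in an ADME assay on Vero cells (Chlorocebus sabaeus) for cytotoxicity, read by MTT assay, with a stated time of 72 h (a higher number here means that more compound is tolerated, a lower number that less compound is tolerated), where compound 3 gives 500 ug/mL. It stands level with compound 2 `COc1c(N2CCN(CC(C)=O)C(C)C2)c(F)cc2c(=O)c(C(=O)O)cn(C3CC3)c12`, which gives 500 ug/mL, the two together being the highest of the three numbers; compound 1 `COc1c(N2CCN(CC#N)C(C)C2)c(F)cc2c(=O)c(C(=O)O)cn(C3CC3)c12` gives 354 ug/mL, and the step is a 1.4-fold higher number from compound 1 to compound 3 (0.15 log units; within the scatter). The next compound, compound 4 `COc1c(N2CCN(CC/C(C)=N/Nc3ccccc3)C(C)C2)c(F)cc2c(=O)c(C(=O)O)cn(C3CC3)c12`, carries a group of 11 heavy atoms (9 carbon, 2 nitrogen; one six-membered aromatic ring of carbon only) in place of a group of 7 heavy atoms (3 carbon, 3 nitrogen, 1 oxygen; no ring), on a saturated chain carbon bound to an amine nitrogen in a ring. Going by the values given here, the steps that bear on this change all touch the same position: a 1.4-fold higher number from compound 1 to compound 2 (0.15 log units; within the scatter), a 1.4-fold higher number from compound 1 to compound 3 (0.15 log units; within the scatter) and no change at the digits printed from compound 2 to compound 3 (within the scatter). Every one of them lies within the scatter, so no step beyond the scatter is expected in this assay for compound 4. Compound 4 is expected to give 450 ug/mL, with a range from 220 ug/mL to 600 ug/mL. The expected step is then a 1.1-fold lower number from compound 3 to compound 4 (0.05 log units; within the scatter).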

Compound 4, half-maximal cytotoxic concentration: 62.5 ug/mL
Compound 4: middle estimate off by 7.2-fold (0.86 log units), on the high side; measured number outside the range, below it.
By their numbers in this assay, from the lowest: compound 4; then compounds 1, 2 and 3 (each within the scatter of the next).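

In this assay, the position on a saturated chain carbon bound to an amine nitrogen in a ring turns out not to be indifferent to its group, which compound 1, compound 2 and compound 3 had not shown: the group with one six-membered aromatic ring of carbon only brings an 8.0-fold lower number from compound 3 to compound 4 (0.90 log units; beyond the scatter), an 8.0-fold lower number from compound 2 to compound 4 (0.90 log units; beyond the scatter) and a 5.7-fold lower number from compound 1 to compound 4 (0.75 log units; beyond the scatter). Only compound 4 stands apart beyond the scatter. Nothing available here accounts for this step.

As far as these compounds go, whether the step follows the aromatic ring itself or the rest of the entering group stays open. A cyclohexyl group or a pyridine ring at this place would bear on that question.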